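The compounds below may be only part of what the source reports. "The series", "measured", "known", "first", "only" and "open" are said of these compounds alone.

Measured compounds:
Compound 1, `Cn1cnnc1SCC(=O)Nc1ccc(-c2nc(-c3ccccc3)c(-c3ccccc3)n2C)cc1` — 89.3%
Compound 2, `Cn1nnnc1SCC(=O)Nc1ccc(-c2nc(-c3ccccc3)c(-c3ccccc3)n2C)cc1` — 77.7%

In a functional assay on MCF7 cells (Homo sapiens) for cytotoxicity, read by MTT assay, with a stated time of 24 h, tested at 80 ug/mL (on this read-out lower numbers stand for a weaker effect and higher numbers for a stronger effect at the one concentration tested), compound 2 stands at the lower of the two numbers. Among the measured compounds shown here, the only measured step, a number 11.6 percentage points lower from compound 1 to compound 2 (beyond the scatter), shows that exchanging the ring attached to the sulfur moves the read-out modestly, though beyond the scatter.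

Compound 3, `Cc1nnc(SCC(=O)Nc2ccc(-c3nc(-c4ccccc4)c(-c4ccccc4)n3C)cc2)s1`, differs from compound 2 in one place: 5-methyl-1,3,4-thiadiazol-2-yl in place of 1-methyl-1H-tetrazol-5-yl on a sulfur. For the measured compounds named here, the step from compound 1 to compound 2 bears on this change only loosely, since it also swaps the ring on the sulfur, but the entering ring here is a different one, and no measured pair covers the thiadiazole itself. Going by the values given here, with one modest step as the only guide, the expected change in this assay is small and may fall within the scatter, in either direction.

Compound 3 is therefore estimated at 80%, with a range from 62% to 95%. That estimate means an expected step of a number 2.3 percentage points higher from compound 2 to compound 3 (within the scatter), within the scatter.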

Compound 3, a percentage reported as activity, at one concentration (the size of the read-out at that concentration, not a potency): 85.2%
Beside the measured number, compound 3's estimate is 5.2 percentage points below it; low and high end bracket the measured number.
By their numbers in this assay, from the lowest: compounds 2, 3 and 1 (each within the scatter of the next, the first and the last beyond it).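

In this assay the exchange of 1-methyl-1H-tetrazol-5-yl for 5-methyl-1,3,4-thiadiazol-2-yl gives a number 7.5 percentage points higher from compound 2 to compound 3 (within the scatter) and the exchange of 4-methyl-4H-1,2,4-triazol-3-yl for the same ring gives a number 4.1 percentage points lower from compound 1 to compound 3 (within the scatter) so compound 3 cannot be told apart from either of the other two, even though those two differ beyond the scatter. This shows that the position on the sulfur also takes a ring carrying a sulfur atom and its methyl on a ring carbon, with the read-out remaining in the range of the two nitrogen-rich rings. Nothing available explains why these rings compare as they do.

The compounds shown leave open how the read-out responds when a simple amine or a carboxylic acid takes the place of the ring on the sulfur, or when a longer chain replaces the ring's methyl. Going by these compounds, with one concentration per compound, whether the effect would be stronger or weaker at other concentrations also remains open.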